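The compounds below may be only part of what the source reports. "The series", "measured", "known", "first", "only" and "open" are said of these compounds alone.

Among the measured compounds shown here, compound 1 `CN(C)CCCNc1nc(-c2ccc(NC(=O)Nc3ccccc3Cl)cc2)nc2c(Cl)c(Cl)sc12` gives 1560 nM in a functional assay on MDA-MB-231 cells (Homo sapiens) for cytotoxicity, read by MTT assay, with a stated time of 72 h (on this read-out higher numbers stand for weaker inhibition and lower numbers for stronger inhibition), the lower of the two numbers recorded; compound 2 `CN(C)CCCNc1nc(-c2ccc(NC(=O)Nc3ccc(Cl)cc3Cl)cc2)nc2c(Cl)c(Cl)sc12` gives 3490 nM, and the one step recorded, a 2.2-fold higher number from compound 1 to compound 2 (0.35 log units; beyond the scatter), concerns a substituent on an aromatic carbon. Compound 3 `CN(C)CCNc1nc(-c2ccc(NC(=O)Nc3ccccc3Cl)cc2)nc2c(Cl)c(Cl)sc12` differs from compound 1 by dimethylamino in place of (dimethylamino)methyl on a saturated chain carbon, two bonds along the chain from a nitrogen on an aromatic ring. For the measured compounds named here, no measured step bears on this shortening of the chain, and the step from compound 1 to compound 2 touches a different part of the molecule. Compound 3 is therefore expected to move only within the scatter, a step of a 1.0-fold higher number from compound 1 to compound 3 (0.01 log units; within the scatter), estimated at 1600 nM within 500 nM to 5000 nM.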

Compound 3, half-maximal inhibitory concentration: 1350 nM
Compound 3: the middle estimate sits 1.2-fold (0.07 log units) above what was measured, and the stated range covers the measured number.
By their numbers in this assay, from the lowest: compounds 3 and 1 (each within the scatter of the next); then compound 2.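

Among the compounds shown here, the step gives a 1.2-fold lower number from compound 1 to compound 3 (0.06 log units; within the scatter) in this assay, the first reading at this chain position, where the earlier compounds differed only on an aromatic carbon. Between 3-(dimethylamino)propyl and 2-(dimethylamino)ethyl, the number therefore does not separate the two chain lengths. Nothing available accounts for this result.

Going by these compounds, it remains open whether a longer chain such as 4-(dimethylamino)butyl, or a piperidine or morpholine in place of the dimethylamino group, would also stay within the scatter. On these data alone, it is also open whether 2-(dimethylamino)ethyl would read the same with the extra chloro of compound 2.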